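This account rests on a few compounds, and the source may have more. Where it says the series, first, only, none or still open, it means among the compounds named here.

Compound 1 `CNC(=O)c1cc(C(=O)NC2CC2)cn(Cc2cccc([C@@H](C)O)c2)c1=O` carries the shared core with a 3-(1-hydroxyethyl)phenyl group. In a physicochemical assay for solubility (on this read-out lower numbers stand for lower solubility and higher numbers for higher solubility), compound 1 gives >= 131 ug/mL, which is a limit of the assay rather than a number. Compound 2 `CNC(=O)c1cc(C(=O)NC)c(=O)n(Cc2ccccc2)c1` likewise sits at a limit, >= 118 ug/mL. Compound 3 `CNC(=O)c1cc(C(=O)NC(C)C)cn(Cc2ccccc2)c1=O` also stands at a limit, >= 136 ug/mL. The one counted step among these, a step that the two limits leave unreadable from compound 2 to compound 3, cannot be read from its two limits. Compound 4 `CNC(=O)c1cc(C(=O)NC2CC2)cn(Cc2cccc(C)c2)c1=O` differs from compound 1 in one place: methyl in place of 1-hydroxyethyl on an aromatic carbon. Among the measured compounds shown here, no measured step mirrors this change, and compound 1 itself gives only a limit. For compound 4 the expected step is therefore an at least 1.4-fold lower number from compound 1 to compound 4 (0.16 log units; that floor lies within the scatter), a modest loss resting on little evidence. Compound 4 is estimated at 90 ug/mL, spanning 30 ug/mL to 150 ug/mL, with a fair chance that the assay again reports only a limit.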

Compound 4, solubility: >= 205 ug/mL
Compound 4 gave a limit, no number; the forecaster's own chance of this, stated with the estimate: 40%; middle value at least 2.2-fold (0.35 log units) away from the limit.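

Among the compounds shown here, compound 1 and compound 4 both stand at limits in this assay, so no step between them can be read. The compounds shown leave open whether methyl in place of 1-hydroxyethyl changes this read-out at all.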